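Halogen swap on the second ring of a pyrazole hydroxamate pair

This account rests on a few compounds, and the source may have more. Where it says the series, first, only, none or still open, it means among the compounds named here.

Compound 1: `O=C(NOCc1ccccc1F)c1cn(-c2ccccc2)nc1-c1ccc(Cl)cc1`, 126000 nM
Compound 2: `O=C(NOCc1ccccc1Cl)c1cn(-c2ccccc2)nc1-c1ccc(Cl)cc1`, 129000 nM

The measured pair is assessed in an ADME assay on HEK-293T cells (Homo sapiens) for antiproliferative activity, read by MTT assay, with a stated time of 48 h, in the presence of a further agent that is not named here; a lower number here means that less compound is tolerated, a higher number that more compound is tolerated. In this assay compound 1 gives 126000 nM, and compound 2 gives 129000 nM. For the measured compounds named here, the single step between them, a 1.0-fold higher number from compound 1 to compound 2 (0.01 log units; within the scatter), is a change of chloro for fluoro on one aromatic carbon of the benzyl side. Compound 2 has the higher of the two numbers, but its gap to compound 1 lies within the scatter, so the two compounds are indistinguishable here.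

Compound 3, `O=C(NOCc1ccccc1Cl)c1cn(-c2ccccc2)nc1-c1ccc(F)cc1`, keeps the chlorine of compound 2 on the benzyl side and changes the other ring: fluoro in place of chloro on an aromatic carbon. The same difference, cut one bond further out, reads 4-chlorophenyl to 4-fluorophenyl. Going by the values given here, the only measured step that bears on this change is the halogen swap between compound 1 and compound 2, which was negligible, although it sat on a different ring. Among the compounds with values here, with no direct precedent, a step of no consequence beyond the scatter is expected. Compound 3 is therefore estimated at 120000 nM, with a range from 60000 nM to 240000 nM, which means an expected step of a 1.1-fold lower number from compound 2 to compound 3 (0.03 log units; within the scatter).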

Compound 3, half-maximal cytotoxic concentration: 44700 nM
Beside the measured number, compound 3's estimate is 2.7-fold (0.43 log units) above it, outside the stated range (below it).
By their numbers in this assay, from the lowest: compound 3; then compounds 1 and 2 (each within the scatter of the next).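

In this assay the halogen on the 4-chlorophenyl ring turns out to be a place where the number can move: the step of a 2.9-fold lower number from compound 2 to compound 3 (0.46 log units; beyond the scatter) comes with fluoro in place of chloro on an aromatic carbon para to a large group. The related exchange on the benzyl side, a 1.0-fold higher number from compound 1 to compound 2 (0.01 log units; within the scatter) and within the scatter, left its two compounds indistinguishable, so in this small set the outcome of a swap between these two halogens depends on the ring that carries it, and the quiet result on one ring does not carry over to the other. For the compounds shown here, with only one step on each ring, this is a contrast between two pairs and not a general rule, and no measurement given here accounts for the larger step.

The compounds shown leave open whether the lower number belongs to fluoro in particular or whether the number would also shift with a methyl group, a methoxy group or an amine on that same carbon. They also leave open whether the step would hold with fluoro in place of chloro on the benzyl side.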